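Replacing the fused bicyclic amine in a bradykinin B1 antagonist

The source may report more compounds than this note shows. Statements on the series, on what has been measured and on what is new or still open speak of the compounds shown alone.

Measured compounds:
compound 1 `Cc1ccc(S(=O)(=O)N2C=CNC(=O)[C@H]2CC(=O)NC2CCNc3ccccc32)cc1`: 21.6 nM
compound 2 `CC(=O)N1CCC(NC(=O)C[C@@H]2C(=O)NC=CN2S(=O)(=O)c2ccc(C)cc2)c2ccccc21`: 72.2 nM
compound 3 `Cc1ccc(S(=O)(=O)N2C=CNC(=O)[C@H]2CC(=O)N[C@@H]2CCC(O)c3ccccc32)cc1`: 1.47 nM

In an in vitro functional assay on cells for antagonist activity at B1 bradykinin receptor (Homo sapiens), read by luminescence and calcium flux, with a stated time of 2 h (a higher number here means a weaker inhibitor, a lower number a stronger inhibitor), compound 1 stands second highest of the three numbers; compound 2 gives a higher number (a 3.3-fold higher number from compound 1 to compound 2 (0.52 log units; beyond the scatter)), while compound 3 gives a lower number than compound 1. Compound 4 `CCN1CC[C@H](NC(=O)C[C@@H]2C(=O)NC=CN2S(=O)(=O)c2ccc(C)cc2)C(C)(C)C1` differs from compound 1 by a group of 10 heavy atoms (9 carbon, 1 nitrogen; one six-membered non-aromatic ring with 1 hetero atom) in place of a group of 10 heavy atoms (9 carbon, 1 nitrogen; one six-membered non-aromatic ring with 1 hetero atom, one six-membered aromatic ring of carbon only), on an amide-type nitrogen. Going by the values given here, no measured step matches this change, which removes the aromatic ring altogether; the only measured step, from compound 1 to compound 2, alters the same part of the molecule and shifts the number modestly upward. A larger upward shift is therefore expected, a 5.6-fold higher number from compound 1 to compound 4 (0.74 log units; beyond the scatter), so compound 4 is estimated at 120 nM, with a range from 25 nM to 600 nM.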

Compound 4, half-maximal inhibitory concentration: 0.63 nM
Estimate against measurement, compound 4: 190-fold (2.28 log units) above; measured number outside the range, below it.
By their numbers in this assay, from the lowest: compound 4; then compound 3; then compound 1; then compound 2.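

In this assay, the aromatic ring on this amide-type nitrogen proves unnecessary for a low number: losing it in the change gives a 34-fold lower number from compound 1 to compound 4 (1.54 log units; beyond the scatter) and the step is large. The earlier step in this part of the molecule went upward, whereas this one shows that the same place can also move the number strongly downward. Nothing available here explains the gain. Which part of the entering group carries the gain remains open, since no compound separates its ethyl group from its two ring methyl groups. As far as these compounds go, whether a propyl chain or a carboxylic acid on the ring nitrogen would hold the number also remains open.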